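The source may report more compounds than this note shows. Statements on the series, on what has been measured and on what is new or still open speak of the compounds shown alone.

Compound 2, `Nc1cc(N)c2nc(-c3ccccc3)c(NCc3ccc(F)cc3)nc2c1`, gives 22400 nM in a functional assay on NCI-H226 cells (Homo sapiens) for inhibition, read by sulforhodamine B assay, with a stated time of 48 h; a higher number here means a weaker inhibitor of growth, a lower number a stronger inhibitor of growth. Among the measured compounds shown here, of the two compounds measured so far it carries the higher number; its nearest neighbour is compound 1, `COc1ccc(CNc2nc3cc(N)cc(N)c3nc2-c2ccccc2)cc1OC`, which in this assay gives 14500 nM, and the step of a 1.5-fold higher number from compound 1 to compound 2 (0.19 log units; within the scatter) lies within the scatter. Compound 3, `Nc1cc(N)c2nc(-c3ccccc3)c(Oc3ccc(F)cc3)nc2c1`, differs from compound 2 by 4-fluorophenoxy in place of (4-fluorobenzyl)amino on an aromatic carbon. For the measured compounds named here, the only measured step, a 1.5-fold higher number from compound 1 to compound 2 (0.19 log units; within the scatter), exchanges one aryl group for another while keeping the (benzyl)amino linker, so it bears on the present change only in showing that this part of the molecule tolerated a variation without a shift beyond the scatter. Going by the values given here, no measured step replaces the amino linker by an oxygen linker, so the direction of this change is untested. Compound 3 is therefore expected to give roughly the same number as compound 2, estimated at 25000 nM with a range of 9000 nM to 70000 nM, meaning an expected step of a 1.1-fold higher number from compound 2 to compound 3 (0.05 log units; within the scatter).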

Compound 3, concentration for 50% growth inhibition: 20400 nM
For compound 3 the middle estimate is 1.2-fold (0.09 log units) above the measured one, and the stated range covers the measured number.
By their numbers in this assay, from the lowest: compounds 1, 3 and 2 (each within the scatter of the next).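

In this assay, among the compounds shown here, the step of a 1.1-fold lower number from compound 2 to compound 3 (0.04 log units; within the scatter) is the first measured change to the linker itself on this aromatic carbon, where the earlier step changed only the aryl group. It shows that the oxygen of 4-fluorophenoxy can stand in for the nitrogen and saturated chain carbon of (4-fluorobenzyl)amino, and that losing the hydrogen-bond donor of the group that leaves produces no difference beyond the scatter. No measurement given here speaks to why this exchange makes so little difference.

Going by these compounds, whether any group on this carbon can move the number beyond the scatter stays open; a bare amine, a morpholine or a longer chain to the aryl ring would test that. On these data alone, the role of the phenyl group also stays open, since it is the same in all three compounds, as is the rest of the shared core.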